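Swapping the Ring on the Imide Nitrogen

The source may hold more compounds than are shown below. What is called first, only, known or untested is meant among the compounds shown, and "the series" means these compounds.

Three compounds have so far been measured in a functional assay on A549 cells (Homo sapiens) for antiproliferative activity, read by MTT assay, with a stated time of 48 h; a higher number here means a weaker inhibitor, a lower number a stronger inhibitor:

compound 1, `Cn1cc(C2=C(c3nn(CCn4ccnc4)c4ncccc34)C(=O)NC2=O)c2ccccc21`, gives > 100000 nM
compound 2, `Cn1cc(C2=C(c3nn(CCCN4CCCCC4)c4ncccc34)C(=O)N(c3ccccn3)C2=O)c2ccccc21`, gives > 100000 nM
compound 3, `Cn1cc(C2=C(c3nn(CCCO)c4ncccc34)C(=O)NC2=O)c2ccccc21`, gives > 100000 nM

Where compound 2 stands is simple: in this assay compound 2 gives > 100000 nM, and that is a limit of the assay, not a number. The same holds for compound 1, whose > 100000 nM is a limit. Compound 3, with > 100000 nM, likewise reaches only a limit. In short, (the limit of > 100000 nM in this assay, at which 3 of the 3 values shown sit). Among the measured compounds shown here, the single step between two measured compounds, a step that the two limits leave unreadable from compound 1 to compound 3, is therefore unreadable: both ends are limits, so its size cannot be told.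

Compound 4, `COc1ccc(N2C(=O)C(c3cn(C)c4ccccc34)=C(c3nn(CCCN4CCCCC4)c4ncccc34)C2=O)cc1`, is yet to be measured. It differs from compound 2 in one place: 4-methoxyphenyl in place of pyridin-2-yl on an amide-type nitrogen in a ring. For the measured compounds named here, no measured step touches this position, and the one step that is known concerns a different part of the molecule and is itself unreadable. There is thus nothing in the numbers to suggest that the change from compound 2 to compound 4 moves the value off the limit.

Compound 4 is accordingly expected to give about 100000 nM, within 20000 nM to 300000 nM. The step of a number no higher from compound 2 to compound 4 (the limit leaves the size open) is expected to amount to nothing beyond the scatter.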

Compound 4, half-maximal inhibitory concentration: 30300 nM
Compound 4: middle estimate off by 3.3-fold (0.52 log units), on the high side; the measured number falls inside the stated range.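

In this assay, 4-methoxyphenyl in place of pyridin-2-yl on the amide-type nitrogen gives an at least 3.3-fold lower number from compound 2 to compound 4 (0.51 log units; beyond the scatter), so this position can move the value off the limit, which no earlier comparison could show. For compound 2, > 100000 nM is a limit, so the step has a smallest size but no upper one. Compound 4 is the only compound shown with a value off the limit: the limit of > 100000 nM in this assay, at which 3 of the 4 values shown sit.

The two groups have the same hydrogen-bond donor and acceptor counts and no net charge, so those counts do not separate them, and the compounds shown cannot tell whether the step belongs to the methoxy group, to the ring of carbon only, or to both, which an unsubstituted phenyl or a 4-aminophenyl on the same nitrogen would begin to separate. Among the compounds shown here, they also leave open whether 4-methoxyphenyl on that nitrogen would act in the same way with the other chains on the shared core, such as the one bearing 1H-imidazol-1-yl in compound 1.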